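The compounds below may be only part of what the source reports. "The series", "measured", "known", "first", "only" and "open" are said of these compounds alone.

In a functional assay on DLD-1 cells (Homo sapiens) for antiproliferative activity, read by CellTiter-Glo, with a stated time of 72 h (on this read-out lower numbers stand for stronger inhibition and higher numbers for weaker inhibition), compound 1 `Cc1cc(C)c(S(=O)(=O)N2CCN(C3CN4CCC3CC4)CC2)c(C)c1` gives 84 nM. In this assay compound 2 `CCc1cc(Br)ccc1S(=O)(=O)N1CCC(N2CCC(C)CC2)CC1` gives 0.6 nM, the lower of the two numbers, and the gap to compound 1 lies well beyond the scatter. Compound 3 `CC1CCN(C2CCN(S(=O)(=O)c3ccc(Br)cc3OC(F)(F)F)CC2)CC1` differs from compound 2 by trifluoromethoxy in place of ethyl on an aromatic carbon. No comparable change has been measured among these compounds, so the step is expected to be small, from compound 2 to compound 3 a 2.5-fold higher number from compound 2 to compound 3 (0.40 log units; beyond the scatter), a rise at most near the edge of the scatter. Compound 3 is therefore estimated at 1.5 nM, with a range from 0.3 nM to 8 nM.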

Compound 3, half-maximal inhibitory concentration: 5 nM
Estimate against measurement, compound 3: 3.3-fold (0.52 log units) below, within the range that was stated.
By their numbers in this assay, from the lowest: compound 2; then compound 3; then compound 1.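

In this assay, trifluoromethoxy in place of ethyl on this aromatic carbon, ortho to a large group and meta to a bromo group, gives an 8.3-fold higher number from compound 2 to compound 3 (0.92 log units; beyond the scatter), so this position is sensitive to the change, although the step is only modest. Ethyl is the better of the two groups here. Nothing measured explains the step. The compounds shown leave open how methoxy or trifluoromethyl would behave on this carbon, which would separate the oxygen from the fluorines. They also leave open whether a longer chain such as propyl would be accepted there.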